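Carbamate Sulfamates as Sterol O-Acyltransferase Inhibitors

This account rests on a few compounds, and the source may have more. Where it says the series, first, only, none or still open, it means among the compounds named here.

Compound 1, `CC(C)c1cccc(C(C)C)c1OC(=O)NS(=O)(=O)N1CCCC1`: 53000 nM
Compound 2, `CC(C)c1cccc(C(C)C)c1OC(=O)NS(=O)(=O)Oc1c(F)cccc1F`: 38000 nM

Both measured compounds were tested in an assay on liver for inhibition of sterol O-acyltransferase 1 (Rattus norvegicus), using microsomes; on this read-out higher numbers stand for weaker inhibition and lower numbers for stronger inhibition. Within the data shown here, compound 2 holds the lowest of the two numbers, and its nearest neighbour is compound 1, but the only measured step, a 1.4-fold lower number from compound 1 to compound 2 (0.14 log units; within the scatter), lies within the scatter, so the two compounds are not separated on this read-out.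

Compound 3, `Cc1cccc(C)c1OS(=O)(=O)NC(=O)Oc1c(C(C)C)cccc1C(C)C`, has not yet been measured. It differs from compound 2 in one place: 2,6-dimethylphenyl in place of 2,6-difluorophenyl on an oxygen. Among the measured compounds shown here, no measured step bears on this change, since the one known step concerns a different group on the sulfonyl sulfur and was itself within the scatter. The account therefore expects no step beyond the scatter from compound 2 to compound 3, a 1.1-fold lower number from compound 2 to compound 3 (0.02 log units; within the scatter).

On that basis compound 3 is estimated at 36000 nM in this assay, with a range from 12000 nM to 110000 nM.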

Compound 3, half-maximal inhibitory concentration: > 50000 nM
Compound 3 was reported as a limit; the forecaster's own chance of this, stated with the estimate: 15%; at least 1.3-fold (0.14 log units) between middle value and limit.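

Compound 3 is reported in this assay only as a limit, not as a number: the limit of > 50000 nM in this assay, at which 1 of the 3 values shown sits. Among these compounds, with 2,6-dimethylphenyl in place of 2,6-difluorophenyl on an oxygen, the data show an at least 1.3-fold higher number from compound 2 to compound 3 (0.11 log units; that floor lies within the scatter), which gives the first reading at this position, although its floor does not separate the two compounds. The change therefore brings no readable gain in inhibition over compound 2, and the step between compound 1 and compound 3 cannot be read.

As far as these compounds go, it remains open how far the true value of compound 3 lies past its limit. From the compounds shown here alone, it is also open whether another group on this oxygen, such as a plain phenyl or a longer alkyl chain, would give a number clearly separated from compound 2.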